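The source may report more compounds than this note shows. Statements on the series, on what has been measured and on what is new or still open speak of the compounds shown alone.

Compounds measured so far in a functional assay on MCF7 cells (Homo sapiens) for cytotoxicity, read by MTT assay, with a stated time of 24 h; a lower number here means a stronger inhibitor, a higher number a weaker inhibitor:
compound 1 `Cn1c(-c2ccc(NC(=O)CSc3nc4cc(Cl)ccc4o3)cc2)nc(-c2ccccc2)c1-c1ccccc1`: 21.7 ug/mL
compound 2 `Cc1ccc2oc(SCC(=O)Nc3ccc(-c4nc(-c5ccccc5)c(-c5ccccc5)n4C)cc3)nc2c1`: 22.4 ug/mL

Compound 2 stands level with compound 1, as their two values lie within the scatter of each other. The next compound is compound 3 `Cn1cnnc1SCC(=O)Nc1ccc(-c2nc(-c3ccccc3)c(-c3ccccc3)n2C)cc1`, which has 4-methyl-4H-1,2,4-triazol-3-yl in place of 5-methyl-1,3-benzoxazol-2-yl on a sulfur. The rest of the structure is unchanged.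

Among the compounds with values here, only one measured step is available: a 1.0-fold higher number from compound 1 to compound 2 (0.01 log units; within the scatter), which lies within the scatter. That step is methyl in place of chloro on an aromatic carbon, so it bears on this change only indirectly. Within the data shown here, it shows no response to that small substitution, but no measured compound tests the replacement of the whole group on the sulfur. The direction is therefore poorly supported, and only a modest move towards a higher number is expected, with a wide margin on both sides. The expected change is a 1.3-fold higher number from compound 2 to compound 3 (0.11 log units; within the scatter). For compound 3 the estimated value in this assay is 29 ug/mL, with an expected range of 11 ug/mL to 80 ug/mL.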

Compound 3, half-maximal inhibitory concentration: 3.2 ug/mL
Estimate against measurement, compound 3: 9.1-fold (0.96 log units) above, outside the stated range (below it).
By their numbers in this assay, from the lowest: compound 3; then compounds 1 and 2 (each within the scatter of the next).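

In this assay, the group on the sulfur turns out to be a place where the number responds strongly, which the methyl for chloro exchange between compound 1 and compound 2 gave no sign of. The replacement by 4-methyl-4H-1,2,4-triazol-3-yl gives a 7.0-fold lower number from compound 2 to compound 3 (0.85 log units; beyond the scatter), and against the chloro partner, 5-chloro-1,3-benzoxazol-2-yl, it gives a 6.8-fold lower number from compound 1 to compound 3 (0.83 log units; beyond the scatter), so both steps are beyond the scatter and of about the same size whichever of the two groups leaves. No measurement on hand explains this gain.

The change alters several things at once, going from two rings to one, from 10 heavy atoms to 6, and from one ring nitrogen to three, and the compounds shown cannot separate these contributions. From the compounds shown here alone, it remains open whether a single ring with fewer nitrogens, such as phenyl or pyridyl, keeps the lower number on the sulfur, whether the methyl on the triazole is needed, and how an open chain ending in an amine or a carboxylic acid would read at this place.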